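The compounds below may be only part of what the source reports. "The series", "measured", "known", "first", "only" and "open" are said of these compounds alone.

Measured so far in an ADME assay on BaF3 cells (Mus musculus) for antiproliferative activity, read by CCK-8 assay, with a stated time of 72 h; on this read-out lower numbers stand for stronger inhibition of growth and higher numbers for weaker inhibition of growth:
compound 1 `O=C(CCSc1ccc2c(/C=C/c3ccccn3)n[nH]c2c1)Nc1cccc(C(F)(F)F)c1`: 2300 nM
compound 2 `Cc1ccc(NC(=O)CCSc2ccc3c(/C=C/c4ccccn4)n[nH]c3c2)cc1`: > 10000 nM, which is a limit of the assay, not a number

Among the compounds with values here, compound 1 carries the only number in this assay; the other value is a limit (the limit of > 10000 nM in this assay, at which 1 of the 2 values shown sits). Within the data shown here, the single measured step, an at least 4.3-fold higher number from compound 1 to compound 2 (0.63 log units; beyond the scatter), removes the trifluoromethyl group and weakens growth inhibition. Compound 3 `Cc1cn(Cc2ccc(NC(=O)CCSc3ccc4c(/C=C/c5ccccn5)n[nH]c4c3)cc2C(F)(F)F)cn1` differs from compound 1 by (4-methyl-1H-imidazol-1-yl)methyl in place of hydrogen on an aromatic carbon; the trifluoromethyl group stays in place. Among the measured compounds shown here, no measured step adds a group of this kind, so the one step bears on compound 3 only in that the trifluoromethyl group is kept. Compound 3 is expected to give about 700 nM, within 150 nM to 3500 nM. The expected step is a 3.3-fold lower number from compound 1 to compound 3 (0.52 log units; beyond the scatter).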

Compound 3, concentration for 50% growth inhibition: 1990 nM
Compound 3: the middle estimate sits 2.8-fold (0.45 log units) below what was measured; the measured number falls inside the stated range.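

In this assay, the aromatic carbon ortho to a trifluoromethyl group and para to a large group takes (4-methyl-1H-imidazol-1-yl)methyl in place of hydrogen, with a 1.2-fold lower number from compound 1 to compound 3 (0.06 log units; within the scatter). A group of 7 heavy atoms at this position therefore leaves growth inhibition within the scatter of compound 1. Compound 2 remains a limit of the assay, not a number: the limit of > 10000 nM in this assay, at which 1 of the 3 values shown sits.

Open, from the compounds shown here alone, is whether an amine or a carboxylic acid at this position would give a number beyond the scatter of compound 1. Also open, going by these compounds, is whether the (4-methyl-1H-imidazol-1-yl)methyl group is tolerated without the trifluoromethyl group.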